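The source may hold more compounds than are shown below. What is called first, only, known or untested is meant among the compounds shown, and "the series" means these compounds.

Measured so far:
compound 1, `CC[C@H]1CN(c2nc(N)c(C(N)=O)nc2Cl)CCN1C1CCN(C(=O)c2ccc(Cl)cc2)CC1`: in an in vitro assay on BaF3 cells for displacement of a labelled ligand from C-X-C chemokine receptor type 3 (Homo sapiens) (on this read-out lower numbers stand for stronger inhibition and higher numbers for weaker inhibition), compound 1 gives 76 nM
compound 2, `CC[C@H]1CN(c2nc(N)c(C(=O)NC)nc2Cl)CCN1C1CCN(Cc2ccc(Cl)cc2)CC1`: in this assay compound 2 gives 0.3 nM

Of these two numbers, compound 2 holds the lower one, and the gap to compound 1 is wide and lies far beyond the usual scatter of this assay. Compound 3, `CC[C@H]1CN(c2nc(N)c(C(=O)NCC(C)(C)O)nc2Cl)CCN1C1CCN(Cc2ccc(Cl)cc2)CC1`, has not yet been measured. It differs from compound 2 in one place: 1-hydroxy-1-methylethyl in place of hydrogen on a saturated chain carbon bound to an amide-type nitrogen. For the measured compounds named here, no step between two measured compounds mirrors this change, so the expectation rests on the change itself and on the value of compound 2. Growing a small amide substituent in this way is expected to shift the number in this assay only a little, if at all, and more likely upward than downward. Compound 3 is therefore expected to give 0.6 nM, within a range from 0.15 nM to 3 nM. The expected step from compound 2 to compound 3 is a 2.0-fold higher number from compound 2 to compound 3 (0.30 log units; within the scatter).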

Compound 3, half-maximal inhibitory concentration: 8.4 nM
Compound 3: middle estimate off by 14-fold (1.15 log units), on the low side, and the stated range ends below it.
By their numbers in this assay, from the lowest: compound 2; then compound 3; then compound 1.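

In this assay, adding 1-hydroxy-1-methylethyl on the saturated chain carbon bound to the amide-type nitrogen gives a 28-fold higher number from compound 2 to compound 3 (1.45 log units; beyond the scatter), so this position does not accept every substituent without a cost in the read-out. For the compounds shown here, compound 1 and compound 2 differ in more than one place, so only this pair isolates a change at the amide substituent. No supporting measurement is available to explain the size of this step.

From the compounds shown here alone, it remains open whether the step goes with the hydroxy group or with the added carbon atoms alone, a question that a plain 2-methylpropyl group in the same place would address. Going by these compounds, how an amine or a carboxylic acid in that place would read out also remains open.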